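Swapping the amide aryl group in an adenosine receptor series

The compounds below may be only part of what the source reports. "The series", "measured", "known", "first", "only" and "open" are said of these compounds alone.

Measured compounds:
compound 1 `COc1ccc(-c2cn3ccnc(NC(=O)c4ccccc4)c3n2)cc1` — 1%
compound 2 `O=C(Nc1nc(-c2ccccc2)cn2cc(-c3ccccc3)nc12)c1ccc(Cl)cc1` — 1%

In an assay on cells for displacement of a labelled ligand from adenosine receptor A1 (Homo sapiens), read by scintillation counting, with a stated time of 120 min, tested at 1 uM (a lower number here means less inhibition, a higher number more inhibition at the concentration tested (going by the name of the read-out)), compound 1 gives 1%. Compound 2 gives 1% in this assay, which is level with compound 1 at the digits reported; the two values lie within the usual scatter of each other, so nothing separates them. Both compounds show almost no inhibition at the concentration tested.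

Compound 3 `O=C(Nc1nc(-c2ccccc2)cn2cc(-c3ccccc3)nc12)c1cccs1` has not yet been measured in this assay. It keeps the whole of compound 2 apart from one change on the amide: thiophen-2-yl in place of 4-chlorophenyl on a carbonyl carbon. For the measured compounds named here, no pair of measured compounds differs in a single place, so there is no measured step from which the size of this change could be read. Since both measured compounds sit at the bottom of the range in this assay, the step from compound 2 to compound 3 is expected to be a number 1 percentage points higher from compound 2 to compound 3 (within the scatter), that is, none beyond the scatter. Compound 3 is therefore estimated to give 2% in this assay, with a range from 0% to 12%.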

Compound 3, a percentage reported as inhibition, at one concentration (the size of the read-out at that concentration, not a potency): 5%
Estimate against measurement, compound 3: 3 percentage points below; measured number inside the range.
By their numbers in this assay, from the lowest: compounds 1, 2 and 3 (each within the scatter of the next).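

In this assay, for the compounds shown here, thiophen-2-yl in place of 4-chlorophenyl on a carbonyl carbon gives a number 4 percentage points higher from compound 2 to compound 3 (within the scatter), the first step that can be read at this place, and it does not separate the two compounds. This place in the series therefore accepts a five-membered aromatic ring with one hetero atom in place of a six-membered aromatic ring of carbon only, with no change beyond the scatter, though both compounds show little inhibition at the concentration tested, so a single swap near the floor of the read-out says little about how much this place matters. Nothing available here measures a property of these groups that could account for the result.

Going by these compounds, it remains open whether any other group on this carbonyl carbon, such as a piperidine ring, a benzoic acid carrying a carboxylic acid, or a longer alkyl chain such as hexyl, would give inhibition clearly beyond the scatter. On these data alone, compound 1 differs from compound 2 and compound 3 in more than one place, so its steps to them cannot be read, and the separate contributions of the other groups on the shared core remain unknown.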